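Swapping the pyridyl group on a thiosemicarbazone amidine

The compounds below may be only part of what the source reports. "The series", "measured", "known", "first", "only" and "open" are said of these compounds alone.

Measured compounds:
compound 1 `N/C(=N\NC(=S)N1CCN(c2ccccn2)CC1)c1ccc(F)cn1`: 22.5%
compound 2 `Cc1cccc(/C(N)=N/NC(=S)N2CCCC2)n1`: 8.7%
compound 3 `Cc1ccnc(/C(N)=N/NC(=S)N2CCOCC2)c1`: 39.1%

Three compounds sharing one core were tested in a functional assay on HeLa cells (Homo sapiens) for cytotoxicity, read by MTT assay, with a stated time of 72 h, tested at 1 uM; on this read-out lower numbers stand for less inhibition of growth and higher numbers for more inhibition of growth at the one concentration tested. Compound 1 gives 22.5%, which places it second highest of the three numbers. Compound 2 sits lower, at 8.7%, a gap beyond the scatter, and compound 3 sits higher, at 39.1%, also beyond the scatter. No pair among these three differs in only one place, so no single step can be read directly from them.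

Compound 4 `Cc1ccnc(/C(N)=N/NC(=S)N2CCN(c3ccccn3)CC2)c1` has not yet been measured. It differs from compound 1 in one change: 4-methylpyridin-2-yl in place of 5-fluoropyridin-2-yl on a carbon with a double bond to nitrogen. Compound 3 carries the same 4-methylpyridin-2-yl group at that place and gave the highest number of the three, but its remaining part also differs from compound 1, so that value alone cannot fix the step. A modest rise is expected from compound 1 to compound 4, about a number 5.5 percentage points higher from compound 1 to compound 4 (within the scatter), which may not exceed the scatter. Compound 4 is therefore estimated at 28%, within a range from 10% to 48%.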

Compound 4, percent growth inhibition at one concentration: 40.4%
For compound 4 the middle estimate is 12.4 percentage points below the measured one; low and high end bracket the measured number.
By their numbers in this assay, from the lowest: compound 2; then compound 1; then compounds 3 and 4 (each within the scatter of the next).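

In this assay, going by these compounds alone, the change of 4-methylpyridin-2-yl in place of 5-fluoropyridin-2-yl on a carbon with a double bond to nitrogen gives the first step in this set that can be read on its own: a number 17.9 percentage points higher from compound 1 to compound 4 (beyond the scatter). Within the data shown here, it shows that the group at this place can, with the rest of the molecule unchanged, move growth inhibition by more than the usual scatter, something the earlier compounds could not show since none of them differed in only one place. Nothing measured here explains the step.

The compounds shown leave open whether the step comes from gaining the methyl or losing the fluorine, which an unsubstituted pyridin-2-yl group at this place would help to separate. They also leave open what a methoxy group or an amine on that pyridine ring would give, and whether the same swap has a similar effect with other groups on the thiocarbonyl carbon.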